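Replacing the Ring Methyl with a Methoxyphenyl Group

The compounds below may be only part of what the source reports. "The series", "measured", "known", "first", "only" and "open" are said of these compounds alone.

Measured so far:
compound 1 `CCOC(=O)c1cc(-c2cccc(OC(=O)NC3CCCCC3)c2)n(-c2ccc(OC)cc2)n1`: 103 nM
compound 2 `CCOC(=O)c1cc(-c2cccc(OC(=O)NC3CCCCC3)c2)n(-c2ccc(C(F)(F)F)cc2)n1`: 132 nM
compound 3 `CCOC(=O)c1cc(-c2ccc(OC(=O)NC3CCCCC3)cc2)nn1C`: 316 nM

In an assay on isolated protein for inhibition of Fatty-acid amide hydrolase 1 (Homo sapiens), read by fluorescence, with a stated time of 30 min (a lower number here means a stronger inhibitor, a higher number a weaker inhibitor), compound 3 gives the highest number of the three, beyond the scatter from compound 2 and from compound 1. Compound 4 `CCOC(=O)c1cc(-c2ccc(OC(=O)NC3CCCCC3)cc2)nn1-c1ccc(OC)cc1` differs from compound 3 by 4-methoxyphenyl in place of methyl on an aromatic nitrogen. Among the compounds with values here, no measured step matches this change directly. Within the data shown here, the only measured step, a 1.3-fold higher number from compound 1 to compound 2 (0.11 log units; within the scatter), alters a group on that aryl ring rather than the ring itself. Compounds 1 and 2, which both carry an aryl group on that nitrogen, give lower numbers than compound 3, yet they differ from compound 3 elsewhere as well. A moderate decrease is therefore expected, a 2.1-fold lower number from compound 3 to compound 4 (0.32 log units; beyond the scatter). Compound 4 is estimated at 150 nM, within a range of 60 nM to 400 nM.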

Compound 4, half-maximal inhibitory concentration: 159 nM
Compound 4: the middle estimate sits 1.1-fold (0.03 log units) below what was measured, within the range that was stated.
By their numbers in this assay, from the lowest: compounds 1, 2, 4 and 3 (each within the scatter of the next, the first and the last beyond it).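

In this assay, within the data shown here, this is the first step that replaces the group on the aromatic nitrogen itself, rather than a group on its aryl ring: a 2.0-fold lower number from compound 3 to compound 4 (0.30 log units; within the scatter). The position thus takes 4-methoxyphenyl in place of methyl with a step that stays within the scatter, so compound 3 and compound 4 cannot be ordered. No evidence here explains the size of this step.

The compounds shown leave open how a longer alkyl chain on that nitrogen would read. They also leave open the effect of an amine or a carboxylic acid on the aryl ring there.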